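The source may report more compounds than this note shows. Statements on the series, on what has been measured and on what is new or still open speak of the compounds shown alone.

Working notes on the series. Three compounds have numbers in an assay on isolated protein for inhibition of Amine oxidase [flavin-containing] A (Bos taurus); on this read-out lower numbers stand for stronger inhibition and higher numbers for weaker inhibition. Compound 1 `CCC(=O)N1N=C(c2ccc(C)cc2)CC1c1ccc(OC)cc1` gives 74100 nM. Compound 2 `CCC(=O)N1N=C(c2ccc(OC)cc2)CC1c1ccc(Cl)cc1` gives 832 nM. Compound 3 `CCC(=O)N1N=C(c2ccc(OC)cc2)CC1c1ccc(F)cc1` gives 1000 nM, which puts compound 3 second highest of the three; it sits nearest to compound 2, with a 1.2-fold higher number from compound 2 to compound 3 (0.08 log units; within the scatter), and furthest from compound 1, whose number is far higher and beyond the scatter.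

Compound 4 `CCC(=O)N1N=C(c2ccc(OC)cc2)CC1c1ccc(OC)cc1` is not yet measured. Relative to compound 3 the change is methoxy in place of fluoro on an aromatic carbon, on an aromatic carbon of a six-membered aromatic ring of carbon only, para to a large group. Among the compounds with values here, only one measured step touches this ring: the halogen swap from compound 2 to compound 3, which stayed within the scatter. Within the data shown here, no measured step exchanges a halogen for a methoxy here, and compound 1, which carries a methoxy on the same ring, differs from compound 3 in the other ring as well, so its value and that of compound 3 can only be set side by side, not read as a step.

Given the absence of a bearing step, compound 4 is expected to move by a 4.0-fold higher number from compound 3 to compound 4 (0.60 log units; beyond the scatter), a weakening, with wide uncertainty. The estimate for compound 4 is 4000 nM, with a range from 800 nM to 25000 nM.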

Compound 4, half-maximal inhibitory concentration: 1170 nM
The estimate for compound 4 lay 3.4-fold (0.53 log units) above the measured number, within the range that was stated.
By their numbers in this assay, from the lowest: compounds 2, 3 and 4 (each within the scatter of the next); then compound 1.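

In this assay the position that took fluoro and chloro also accepts methoxy, with a 1.2-fold higher number from compound 3 to compound 4 (0.07 log units; within the scatter) and a 1.4-fold higher number from compound 2 to compound 4 (0.15 log units; within the scatter) both inside the scatter, so the change from 4-fluorophenyl to 4-methoxyphenyl does not separate compound 4 from the two halogen compounds. The large difference in this small set lies on the other aromatic ring, where methoxy in place of methyl gives a 63-fold lower number from compound 1 to compound 4 (1.80 log units; beyond the scatter) and thus shows that compound 1 stands apart through that ring and not through the ring carrying the fluoro, chloro or methoxy group. No supporting measurement bears on the reason for either result.

The compounds shown leave open whether an amine, a carboxylic acid or a longer alkoxy chain on this aromatic carbon would also stay within the scatter of compound 4. On these data alone, the large step on the other ring rests on a single pair, so it remains open whether methyl there has the same consequence when fluoro or chloro occupies the first ring.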